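A hydroxymethyl group gives way to 4-aminophenyl

The source may hold more compounds than are shown below. What is called first, only, known or untested is meant among the compounds shown, and "the series" means these compounds.

Of the compounds shown here, two sharing one core have been measured in an ADME assay on cells (spleen, Mus musculus, strain C57BL/6) for inhibition, read by flow cytometry and propidium iodide staining, with a stated time of 24 h, at 37 degrees C; a lower number here means that less compound is needed, a higher number that more compound is needed for the effect. Compound 1 `O=C(Cn1cc(CO)nn1)NCc1ccccc1` gives 490 uM in this assay. Compound 2 `Nc1cccc(-c2cn(CC(=O)NCc3ccccc3)nn2)c1` carries a 3-aminophenyl group where compound 1 has hydroxymethyl, and in this assay compound 2 gives 800 uM. The step of a 1.6-fold higher number from compound 1 to compound 2 (0.21 log units; within the scatter) shows that these two numbers sit within the usual scatter of each other, so neither compound can be called more or less active than the other on this evidence.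

Compound 3 `Nc1ccc(-c2cn(CC(=O)NCc3ccccc3)nn2)cc1` is the untested neighbour of both. Relative to compound 1, its change is 4-aminophenyl in place of hydroxymethyl on an aromatic carbon. For the measured compounds named here, the only measured step that bears on this change is the one from compound 1 to compound 2, where an aminophenyl group also replaced hydroxymethyl at the same place and the number moved by a 1.6-fold higher number from compound 1 to compound 2 (0.21 log units; within the scatter), a shift inside the scatter. On that basis compound 3 is expected to differ from compound 1 by about a 1.4-fold higher number from compound 1 to compound 3 (0.15 log units; within the scatter), with no movement beyond the scatter anticipated. The estimate for compound 3 in this assay is therefore 700 uM, with a likely range from 350 uM to 1400 uM.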

Compound 3, concentration for half-maximal effect: 1240 uM
Compound 3: middle estimate off by 1.8-fold (0.25 log units), on the low side; the measured number falls inside the stated range.
By their numbers in this assay, from the lowest: compounds 1, 2 and 3 (each within the scatter of the next, the first and the last beyond it).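

For the compounds shown here, with compound 3, replacing hydroxymethyl with an aminophenyl group on this aromatic carbon produces a step that clears the scatter in this assay for the first time (a 2.5-fold higher number from compound 1 to compound 3 (0.40 log units; beyond the scatter)), a modest move towards needing more compound. The change of hydroxymethyl to an aminophenyl group does not carry this result on its own, as compound 2 goes against it (a 1.6-fold higher number from compound 1 to compound 2 (0.21 log units; within the scatter)), while the two aminophenyl groups cannot be separated from each other (a 1.6-fold higher number from compound 2 to compound 3 (0.19 log units; within the scatter)), so the data give a clear difference only for the 4-aminophenyl group against hydroxymethyl and none between the 4-aminophenyl and 3-aminophenyl groups. No measurement accompanies these numbers that would account for the shift.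

The compounds shown leave open whether the amine contributes at all, a question that a plain phenyl group or a phenyl group carrying a carboxylic acid in place of the amine would address. They also leave open how a longer chain ending in a hydroxyl group would compare with hydroxymethyl at this position on the shared core.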